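Amide nitrogen substitution on the shared core

A few compounds are considered here, and "the series" means these few. Any claim that something is new, unique, unknown or untested is made for them only; others in the source may bear on it.

The series shares one core, seen in compound 1 `COc1cccc(CN(CCN(C)C)C(=O)c2n[nH]c3cc(-c4cn[nH]c4)ccc23)c1`, and is followed in an assay on isolated protein for inhibition of Rho-associated protein kinase 2 (Homo sapiens), read by HTRF, with a stated time of 4 h; on this read-out lower numbers stand for stronger inhibition and higher numbers for weaker inhibition. In this assay compound 1 reaches only a limit, < 1 nM, so no number is known for it. Going by the values given here, it is the single compound that sits at the limit of < 1 nM in this assay, at which 1 of the 3 values shown sits. Two further compounds carry the same amide-linked side group on differently built cores. Compound 2 `COc1cccc(CNC(=O)c2n[nH]c3ccc(-c4cn[nH]c4)cc23)c1` gives 67 nM in this assay, and compound 3 `COc1cccc(CNC(=O)c2nc3ccc(-c4cn[nH]c4)cc3[nH]2)c1` gives 4 nM. Neither differs from compound 1 in one place only, so their values stand beside each other without a computed step, and the two of them simply show that secondary amides in this series have been found across a broad range.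

Compound 4 `COc1cccc(CNC(=O)c2n[nH]c3cc(-c4cn[nH]c4)ccc23)c1` is not yet measured. It differs from compound 1 by hydrogen in place of 2-(dimethylamino)ethyl on an amide-type nitrogen. Among the compounds with values here, no measured pair isolates what the substituent on the amide nitrogen contributes, so the expectation rests on the limit for compound 1 and the numbers for compound 2 and compound 3. Compound 4 is expected to give 5 nM, with a range from 1 nM to 30 nM. That estimate means an expected step of an at least 5.0-fold higher number from compound 1 to compound 4 (0.69 log units; beyond the scatter), a loss beyond the usual scatter, though the limit on compound 1 leaves its true size uncertain.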

Compound 4, half-maximal inhibitory concentration: < 1 nM
Compound 4 gave a limit, no number; the forecaster's own chance of this, stated with the estimate: 15%; middle value at least 5.0-fold (0.69 log units) from the limit.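

In this assay compound 4 gives < 1 nM, a limit and not a number, and compound 1 also stands at a limit, so no step can be read between compound 1 and compound 4: the limit of < 1 nM in this assay, at which 2 of the 4 values shown sit. Going by these compounds, what hydrogen in place of 2-(dimethylamino)ethyl on the amide-type nitrogen contributes to inhibition remains open.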